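Compound 4: chloro replaces 4-hydroxy-4-methylpiperidin-1-yl

The source may hold more compounds than are shown below. What is called first, only, known or untested is meant among the compounds shown, and "the series" means these compounds.

Measured so far:
compound 1 `CC(=O)N1CC=C(c2ccn3c(-c4ccc(NC(=O)c5ccc([N+](=O)[O-])o5)cc4)cnc3c2)CC1` — 940 nM
compound 2 `CN1CCN(c2ccn3c(-c4ccc(NC(=O)c5ccc([N+](=O)[O-])o5)cc4)cnc3c2)CC1` — 1580 nM
compound 3 `CC1(O)CCN(c2ccn3c(-c4ccc(NC(=O)c5ccc([N+](=O)[O-])o5)cc4)cnc3c2)CC1` — 3100 nM

In a functional assay on MGC-803 cells (Homo sapiens) for antiproliferative activity, read by CCK-8 assay, with a stated time of 72 h (a lower number here means a stronger inhibitor, a higher number a weaker inhibitor), compound 3 gives the highest of the three numbers shown, though the nearest step, a 2.0-fold higher number from compound 2 to compound 3 (0.29 log units; within the scatter), stays within the scatter; the only step beyond it is a 3.3-fold higher number from compound 1 to compound 3 (0.52 log units; beyond the scatter). Compound 4 `O=C(Nc1ccc(-c2cnc3cc(Cl)ccn23)cc1)c1ccc([N+](=O)[O-])o1` carries chloro in place of 4-hydroxy-4-methylpiperidin-1-yl on an aromatic carbon. Going by the values given here, no measured step removes the ring altogether, so none bears directly on this change; the steps of a 1.7-fold higher number from compound 1 to compound 2 (0.23 log units; within the scatter) and a 2.0-fold higher number from compound 2 to compound 3 (0.29 log units; within the scatter) show only that exchanging one ring for another at this position moved the number modestly. The step to compound 4 is therefore expected to be small, a 1.2-fold lower number from compound 3 to compound 4 (0.09 log units; within the scatter), with wide uncertainty in either direction. Compound 4 is estimated at 2500 nM, in the range 600 nM to 10000 nM.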

Compound 4, half-maximal inhibitory concentration: 4620 nM
Compound 4: the middle estimate sits 1.8-fold (0.27 log units) below what was measured, and the stated range covers the measured number.
By their numbers in this assay, from the lowest: compounds 1, 2, 3 and 4 (each within the scatter of the next, the first and the last beyond it).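

In this assay, chloro, with no ring at this position on an aromatic carbon, stays within the scatter of 4-hydroxy-4-methylpiperidin-1-yl: a 1.5-fold higher number from compound 3 to compound 4 (0.17 log units; within the scatter). Against the other two ring groups the same chloro lies beyond the scatter, with a 2.9-fold higher number from compound 2 to compound 4 (0.47 log units; beyond the scatter) and a 4.9-fold higher number from compound 1 to compound 4 (0.69 log units; beyond the scatter), so the ring groups of compound 1 and compound 2 give lower numbers than chloro, while the ring of compound 3 does not. Nothing available explains these steps. Open, going by these compounds, is whether an open-chain amine or a carboxylic acid here would match compound 1 or go beyond it.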